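A few compounds are considered here, and "the series" means these few. Any claim that something is new, unique, unknown or untested is made for them only; others in the source may bear on it.

Measured so far:
- compound 1 `CCOC(=O)c1ccc(-c2ccc(OCC)cc2)o1`: 50000 nM
- compound 2 `CC(C)OC(=O)Nc1cccc(-c2ccc(N(C)C)cc2)c1`: 82000 nM

In an assay on COS-7 cells for inhibition of patatin-like phospholipase domain-containing protein 2 (Mus musculus) (a lower number here means a stronger inhibitor, a higher number a weaker inhibitor), compound 1 gives 50000 nM and compound 2 gives 82000 nM. Compound 2 carries the higher of the two numbers, yet the gap to compound 1 lies within the scatter, so the two cannot be ranked against each other. Both are weak inhibitors in this assay.

Compound 3 `CN(C)c1ccc(-c2cccc(NC(=O)C(C)(C)C)c2)cc1` differs from compound 2 in a single place: tert-butyl in place of isopropoxy on a carbonyl carbon. The hydrogen-bond acceptor of the isopropoxy group is lost, and the carbonyl carbon now bears a tert-butyl group instead, while the amide-type nitrogen and the rest of the shared core stay as they are.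

Among the compounds with values here, no measured pair shows what this exchange does in this assay, so the expectation must rest on compound 2 alone. The step from compound 2 to compound 3 is estimated to be small and without a clear direction, a 1.2-fold lower number from compound 2 to compound 3 (0.07 log units; within the scatter), most likely staying within the scatter. Compound 3 is therefore expected to give 70000 nM in this assay, with a range from 20000 nM to 250000 nM.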

Compound 3, half-maximal inhibitory concentration: > 200000 nM
Compound 3: a limit, no number (the forecaster's own chance of this, stated with the estimate: 30%); at least 2.8-fold (0.45 log units) between middle value and limit.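

Compound 3 reads > 200000 nM in this assay, which is a limit of the assay and not a number. Replacing isopropoxy with tert-butyl on a carbonyl carbon whose other neighbour is an amide-type nitrogen still gives an at least 2.4-fold higher number from compound 2 to compound 3 (0.38 log units; beyond the scatter), so this position does respond to the group placed there, and the change weakens inhibition. The full size of the step remains unknown because compound 3 can only be read as a limit: the limit of > 200000 nM in this assay, at which 1 of the 3 values shown sits.

The compounds shown leave open whether the loss of the oxygen or the arrival of the fourth carbon matters more, as both happen in the same change. They also leave open whether methoxy or a dimethylamino group on the same carbonyl carbon would give a lower number than compound 2.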